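The compounds below may be only part of what the source reports. "The series", "measured", "known", "first", "only" and "open" are said of these compounds alone.

Measured so far in a functional assay on MDA-MB-231 cells (Homo sapiens) for cytotoxicity, read by sulforhodamine B assay, with a stated time of 72 h; on this read-out higher numbers stand for weaker inhibition of growth and lower numbers for stronger inhibition of growth:

compound 1, `O=C(Nc1ccccc1O)C1CCc2ccccc2N1`: 5260 nM
compound 2, `O=C(Nc1cc(C(F)(F)F)cc(C(F)(F)F)c1)C1CCc2ccccc2N1`: 8270 nM
compound 3, `O=C(Nc1cc(C(F)(F)F)cc(C(F)(F)F)c1)C1CCc2ccccc2N1C(=O)c1cccc(Cl)c1`: 1190 nM

Compound 1 and compound 2 share a secondary amide on the same bicyclic core but differ in the anilide part; the difference between the two cores is not broken down here. In this assay compound 1 gives 5260 nM and compound 2 gives 8270 nM, two numbers that lie within the usual scatter of each other, so no order between them is read.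

Compound 3 carries the change ((3-chlorophenyl)carbonyl in place of hydrogen on a nitrogen on an aromatic ring in a ring). Among the measured compounds shown here, that change made the step of a 6.9-fold lower number from compound 2 to compound 3 (0.84 log units; beyond the scatter), the one step in the set that clearly exceeds the scatter.

Compound 4, `O=C(Nc1ccccc1O)C1CCc2ccccc2N1C(=O)c1cccc(Cl)c1`, is not yet measured. It stands to compound 1 as compound 3 stands to compound 2: the change is (3-chlorophenyl)carbonyl in place of hydrogen on a nitrogen on an aromatic ring in a ring, the same kind of change, with the place described in the same words. The expectation for compound 4 in this assay therefore rests on a single precedent, the step from compound 2 to compound 3, applied to the value of compound 1, which is 5260 nM. For the measured compounds named here, with only one example of the change, and on a different anilide, the expected step is set a little smaller than the measured one. Compound 4 is expected to give about 1000 nM, within 400 nM to 2700 nM, which means an estimated step of a 5.3-fold lower number from compound 1 to compound 4 (0.72 log units; beyond the scatter).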

Compound 4, concentration for 50% growth inhibition: 10600 nM
Estimate against measurement, compound 4: 11-fold (1.03 log units) below; the whole stated range lies below it.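

In this assay, placing (3-chlorophenyl)carbonyl on the ring nitrogen of the core of compound 1 gives a 2.0-fold higher number from compound 1 to compound 4 (0.30 log units; within the scatter), so no effect of the change on growth inhibition can be read for this pair. The change therefore does not carry over as a fixed step between these two anilide parts, and a result from one cannot be transferred to the other as a simple shift in this series: the same change on two cores in this assay, a 6.9-fold lower number (0.84 log units; beyond the scatter) from compound 2 to compound 3 and a 2.0-fold higher number (0.30 log units; within the scatter) from compound 1 to compound 4, 14-fold (1.15 log units) apart, beyond the scatter of two such steps

Among the compounds shown here, this rests on only two matched pairs in one assay, and those pairs differ throughout the anilide part, so the data do not show which feature of that part goes with the gap, why the steps differ, or how the change would behave on any other anilide.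

The compounds shown leave open whether the gap follows the hydroxy group of compound 1 and compound 4 or the two trifluoromethyl groups of compound 2 and compound 3, a question that an anilide bearing a methoxy group, an amine or a single trifluoromethyl group could help to settle. Also open, going by these compounds, is whether the same split appears with a different group on the ring nitrogen, such as acetyl or a longer acyl chain.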